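Three Analogues at the Limit, a Fourth Awaiting Measurement

The source may report more compounds than this note shows. Statements on the series, on what has been measured and on what is new or still open speak of the compounds shown alone.

Compound 1 `CCON/C(=N\C1=NC(=O)C(=O)N1C(C)C)Nc1ccc(Cl)c(Cl)c1`: in an in vitro ADME assay on microsomes from liver (Mus musculus) for metabolic stability, read by LC-MS (a higher number here means that the compound lasts longer, a lower number that the compound disappears faster), compound 1 gives > 1 h, which is a limit of the assay and not a number.
Compound 2 `CN/C(=N\C1=NC(=O)C(=O)N1C(C)C)Nc1ccc(Cl)c(Cl)c1`: compound 2 gives > 1 h, again a limit of the assay.
Compound 3 `CC(C)N/C(=N\C1=NC(=O)C(=O)N1C(C)C)Nc1ccc(Cl)c(Cl)c1`: compound 3 gives > 1 h, also a limit of the assay.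

Compound 1 therefore stands at the limit, and so do its two companions, as the limit of > 1 h in this assay, at which 3 of the 3 values shown sit, records. The step that the two limits leave unreadable from compound 1 to compound 2 and the step that the two limits leave unreadable from compound 1 to compound 3 are both left unreadable by these limits, and the same holds for a step that the two limits leave unreadable from compound 2 to compound 3. Compound 4 `CC(C)N1C(=O)C(=O)N=C1/N=C(\NCCCCN1CCCC1)Nc1ccc(Cl)c(Cl)c1` is the next one to be measured, and it differs from compound 1 by 4-(pyrrolidin-1-yl)butyl in place of ethoxy on an amine nitrogen.

The measured steps that bear on this change are all on the same amine nitrogen, and none of them could be read, since every variation there stays at the limit. No direction can be taken from them, and compound 4 is expected to remain at or near that limit as well. The expected step from compound 1 to compound 4 is a step that the limit leaves unreadable from compound 1 to compound 4, which is to say no change beyond the scatter. Compound 4 is estimated at 1.5 h, in a range from 0.6 h to 4 h.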

Compound 4, half-life: > 1 h
Compound 4 gave a limit, no number (the forecaster's own chance of this, stated with the estimate: 65%); the middle value lies beyond the limit too.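

In this assay compound 4 gives > 1 h as a limit of the assay, not a number. The steps to compound 4 from compound 1, compound 2 and compound 3 therefore cannot be read: the limit of > 1 h in this assay, at which 4 of the 4 values shown sit. The compounds shown leave open how long any of the four lasts beyond that limit, and so whether the groups on the amine nitrogen differ at all.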